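Swapping Trifluoromethyl for Chloro on the Benzyl Ring

The source may hold more compounds than are shown below. What is called first, only, known or untested is meant among the compounds shown, and "the series" means these compounds.

Three measured compounds share a core carrying two trifluoromethyl groups and differ at the benzyl end and in chain length. In a functional assay on BE(2)-C cells (Homo sapiens) for inhibition, read by MTT assay, with a stated time of 72 h (on this read-out higher numbers stand for weaker inhibition of growth and lower numbers for stronger inhibition of growth), compound 2 `O=S(=O)(NCCCNCc1ccc(C(F)(F)F)cc1)c1cc(C(F)(F)F)cc(C(F)(F)F)c1` gives 2700 nM, the second highest of the three numbers. Compound 1 `O=S(=O)(NCCCCNCc1ccc(Br)cc1)c1cc(C(F)(F)F)cc(C(F)(F)F)c1` gives 2200 nM, within the scatter of compound 2, while compound 3 `CC(C)(C)c1ccc(CNCCNS(=O)(=O)c2cc(C(F)(F)F)cc(C(F)(F)F)c2)cc1` gives 14000 nM, a gap beyond the scatter. Compound 4 `O=S(=O)(NCCCNCc1ccc(Cl)cc1)c1cc(C(F)(F)F)cc(C(F)(F)F)c1` differs from compound 2 in one place: chloro in place of trifluoromethyl on an aromatic carbon. Compound 1, with bromo and a longer chain, sits within the scatter of compound 2, so a halogen here is expected to leave the number roughly in place: a 1.1-fold higher number from compound 2 to compound 4 (0.05 log units; within the scatter), no shift beyond the scatter in either direction. Compound 4 is therefore estimated at 3000 nM, with a range from 1200 nM to 7500 nM.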

Compound 4, concentration for 50% growth inhibition: 2900 nM
Compound 4: the middle estimate sits 1.0-fold (0.01 log units) above what was measured; low and high end bracket the measured number.
By their numbers in this assay, from the lowest: compounds 1, 2 and 4 (each within the scatter of the next); then compound 3.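

In this assay, the step of a 1.1-fold higher number from compound 2 to compound 4 (0.03 log units; within the scatter) lies within the scatter, so exchanging 4-(trifluoromethyl)benzyl for 4-chlorobenzyl, with four heavy atoms giving way to one, brings no readable shift at this position. The step of a 1.3-fold higher number from compound 1 to compound 4 (0.12 log units; within the scatter) also lies within the scatter, even though the halogen and the chain length differ together. No measured evidence here explains why the number holds. Still open, on these data alone, is whether an amine or a carboxylic acid in place of chloro on the aromatic carbon would move the number beyond the scatter.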